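This account rests on a few compounds, and the source may have more. Where it says the series, first, only, none or still open, it means among the compounds named here.

In an ADME assay on microsomes from liver (Homo sapiens) for metabolic stability, read by LC-MS, with a stated time of 10 min (on this read-out higher numbers stand for a more stable compound and lower numbers for a less stable compound), the measured compounds stand as follows

- compound 1 `C[C@@H]1CN(c2cccc3c2C[C@H](CN(C)[C@H]2CCCc4cccnc42)NC3)C[C@H](C)N1` gives 100%
- compound 2 `CCN(C[C@H]1Cc2c(cccc2N2CCNCC2)CN1)[C@H]1CCCc2cccnc21` gives 79.1%

Compound 1 is the higher of the two, and the gap down to compound 2 lies beyond the scatter. Compound 3 `C[C@@H]1CN(c2cccc3c2C[C@H](CN(C)[C@H]2CCCc4cccnc42)NC3)C[C@H](C)N1C` carries methyl in place of hydrogen on an amine nitrogen in a ring of compound 1. Within the data shown here, no measured pair shows this change. With compound 1 at 100% an upward move has little room, so a small downward step is expected in this assay at about the edge of the scatter. The estimated step is a number 10 percentage points lower from compound 1 to compound 3 (within the scatter) and no larger one is expected. For compound 3 the expected value is 90% with an estimated range from 72% to 100% on this read-out.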

Compound 3, percent of the compound remaining: 24.6%
Beside the measured number, compound 3's estimate is 65.4 percentage points above it, and the stated range ends above it.
By their numbers in this assay, from the lowest: compound 3; then compound 2; then compound 1.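

In this assay, methyl in place of hydrogen on this amine nitrogen in a ring gives a number 75.4 percentage points lower from compound 1 to compound 3 (beyond the scatter), a large step beyond the scatter. The earlier compounds shown here held no pair with this change, so only now is it seen that the result at this one nitrogen is far from neutral. Nothing at hand accounts for the size of this step.

As far as these compounds go, whether an ethyl or an acetyl on the same nitrogen would give a similar result stays open. So does whether methyl here would have the same outcome in a ring without the two flanking methyl groups.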